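This account rests on a few compounds, and the source may have more. Where it says the series, first, only, none or still open, it means among the compounds named here.

compound 1 `CN(C)CC(=O)N1CCC(NS(=O)(=O)c2cc(S(=O)(=O)c3ccccc3)ccc2C(F)(F)F)CC1`: 100000 nM
compound 2 `O=C(CN1CCCC1)N1CCC(NS(=O)(=O)c2cc(S(=O)(=O)c3ccccc3)ccc2C(F)(F)F)CC1`: 25000 nM

In a physicochemical assay for solubility (a higher number here means a more soluble compound, a lower number a less soluble compound), compound 2 holds the lower of the two numbers. Among the compounds with values here, the only measured step is a 4.0-fold lower number from compound 1 to compound 2 (0.60 log units; beyond the scatter) and it is modest in size, though beyond the scatter. It comes from pyrrolidin-1-yl in place of dimethylamino on a saturated chain carbon bound to a carbonyl carbon.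

Compound 3 `O=C(CN1CCNCC1)N1CCC(NS(=O)(=O)c2cc(S(=O)(=O)c3ccccc3)ccc2C(F)(F)F)CC1` changes that same place again, with piperazin-1-yl in place of pyrrolidin-1-yl, and piperazin-1-yl in place of pyrrolidin-1-yl on a saturated chain carbon bound to a carbonyl carbon gives the full count of that swap. Within the data shown here, no measured compound carries piperazin-1-yl, so the direction remains uncertain. With only a 4.0-fold lower number from compound 1 to compound 2 (0.60 log units; beyond the scatter) to go on, a step of similar modest size is expected, leaning upward toward compound 1 at 100000 nM as a tentative guess. The expected move in this assay is a 2.0-fold higher number from compound 2 to compound 3 (0.30 log units; within the scatter) as a rough estimate. Compound 3 is estimated at 50000 nM with 20000 nM as the lower end and 120000 nM as the upper end of the expected range.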

Compound 3, solubility: 50000 nM
Beside the measured number, compound 3's estimate shows no gap at the digits printed; the range from low to high includes it.
By their numbers in this assay, from the lowest: compounds 2, 3 and 1 (each within the scatter of the next, the first and the last beyond it).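

In this assay, piperazin-1-yl on the saturated chain carbon bound to a carbonyl carbon gives a 2.0-fold higher number from compound 2 to compound 3 (0.30 log units; within the scatter) and a 2.0-fold lower number from compound 1 to compound 3 (0.30 log units; within the scatter). Compound 3 therefore cannot be told apart from either compound 1 or compound 2, even though those two differ from each other beyond the scatter. This holds although the change brings a six-membered ring with 2 hetero atoms and 1 hydrogen-bond donor to a place that earlier held only groups with 0 donors, and no separate measurement offers an explanation for these numbers.

Still open, as far as these compounds go, is whether the donor on piperazin-1-yl matters at all, which a morpholin-4-yl or 4-methylpiperazin-1-yl group at this place could help to test. Also open, from the compounds shown here alone, is whether a longer chain carrying the same amine would give a step beyond the scatter.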